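The compounds below may be only part of what the source reports. "The series", "measured", "known", "first", "only" and "open" are said of these compounds alone.

Compound 1, `Cn1nc2c(=O)n(CC3(O)CCN(Cc4ccc(-c5cnco5)cc4Cl)CC3)cnc2c1-c1ccc(CN)cc1`, in an assay on isolated protein for inhibition of ubiquitin carboxyl-terminal hydrolase 7 (Homo sapiens), with stated times of 30 min and 2 h; on this read-out lower numbers stand for stronger inhibition and higher numbers for weaker inhibition: compound 1 gives 71.6 nM.
Compound 2, `Cn1nc2c(=O)n(CC3(O)CCN(Cc4ccc(C5=CCCC5)cc4Cl)CC3)cnc2c1-c1ccc(CN)cc1`, in this assay: compound 2 gives 76.9 nM.
Compound 3, `Cn1nc2c(=O)n(CC3(O)CCN(Cc4ccc(-c5cccs5)cc4Cl)CC3)cnc2c1-c1ccc(CN)cc1`, in this assay: compound 3 gives 38.6 nM.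

Compound 3 holds the lowest of the three numbers, but its steps to the other two, a 1.9-fold lower number from compound 1 to compound 3 (0.27 log units; within the scatter) and a 2.0-fold lower number from compound 2 to compound 3 (0.30 log units; within the scatter), both lie within the scatter, as does a 1.1-fold higher number from compound 1 to compound 2 (0.03 log units; within the scatter). The three five-membered or carbocyclic groups at this position therefore give numbers that cannot be told apart.

Compound 4, `Cn1nc2c(=O)n(CC3(O)CCN(Cc4ccc(-c5cncs5)cc4Cl)CC3)cnc2c1-c1ccc(CN)cc1`, has not yet been measured. It differs from compound 3 in one place: 1,3-thiazol-5-yl in place of thiophen-2-yl on an aromatic carbon. Among the compounds with values here, the closest precedent is the step from the oxazolyl group of compound 1 to the thienyl group of compound 3, which stayed within the scatter; the new group shares the sulfur of the thiophene and the second ring nitrogen of the oxazole. On this basis compound 4 is expected to stay close to compound 3 in this assay, with a step of a 1.3-fold higher number from compound 3 to compound 4 (0.11 log units; within the scatter). Compound 4 is estimated at 50 nM, within a range of 25 nM to 100 nM.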

Compound 4, half-maximal inhibitory concentration: 117 nM
Compound 4: middle estimate off by 2.3-fold (0.37 log units), on the low side, and the stated range ends below it.
By their numbers in this assay, from the lowest: compounds 3, 1, 2 and 4 (each within the scatter of the next, the first and the last beyond it).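

In this assay this position, on an aromatic carbon meta to a chloro group and para to a large group, separates two closely related five-membered aromatic rings. Within the data shown here, a ring nitrogen in place of a ring carbon, going from thiophen-2-yl to 1,3-thiazol-5-yl, gives a 3.0-fold higher number from compound 3 to compound 4 (0.48 log units; beyond the scatter), the only step in the set beyond the scatter, and a modest one, while a 1.5-fold higher number from compound 2 to compound 4 (0.18 log units; within the scatter) and a 1.6-fold higher number from compound 1 to compound 4 (0.21 log units; within the scatter) both stay within the scatter, so the separation holds only against the thiophen-2-yl group. Nothing in the data given accounts for this step.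

Still open, going by these compounds, is how a ring nitrogen placed elsewhere, as in 1,3-thiazol-2-yl, would read at this position, and whether a six-membered aromatic ring such as pyridin-3-yl would match the thiophen-2-yl group. Also open, on these data alone, is how an open chain such as propyl, or a carboxylic acid, would behave here.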